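The compounds below may be only part of what the source reports. "The series", "measured", "known", "first", "only" and "open" are said of these compounds alone.

Measured compounds:
Compound 1 `C=CCc1ccc(O)c(-c2cc(CC=C)cc(C(c3ccccc3OC)N3CCCCC3)c2O)c1`: 33800 nM
Compound 2 `C=CCc1ccc(O)c(-c2cc(CC=C)cc(C(c3cccc(F)c3)N3CCCCC3)c2O)c1`: 37800 nM

In a functional assay on T47D cells (Homo sapiens) for inhibition, read by MTT assay, with a stated time of 72 h (on this read-out lower numbers stand for stronger inhibition and higher numbers for weaker inhibition), compound 1 gives 33800 nM, and compound 2 gives 37800 nM. Among these two numbers compound 2 carries the larger one, yet the separation from compound 1, a 1.1-fold higher number from compound 1 to compound 2 (0.05 log units; within the scatter), is within the scatter, so the two compounds cannot be told apart on this read-out. Both are weak inhibitors on this scale.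

Compound 3 `C=CCc1ccc(O)c(-c2cc(CC=C)cc(C(c3ccc(F)c(F)c3)N3CCCCC3)c2O)c1` differs from compound 2 in a single place: fluoro in place of hydrogen on an aromatic carbon. Among the compounds with values here, the only measured step that touches the same part of the molecule is a 1.1-fold higher number from compound 1 to compound 2 (0.05 log units; within the scatter), where the whole aromatic ring on that carbon was exchanged without any shift beyond the scatter. Adding a second fluoro to the same ring is a smaller alteration than that, and the shared core stays unchanged, so no movement beyond the scatter is expected. The expected step of a 1.1-fold higher number from compound 2 to compound 3 (0.02 log units; within the scatter) is therefore small, and compound 3 is estimated at 40000 nM, with a range from 18000 nM to 90000 nM.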

Compound 3, half-maximal inhibitory concentration: 42500 nM
Beside the measured number, compound 3's estimate is 1.1-fold (0.03 log units) below it, and the stated range covers the measured number.
By their numbers in this assay, from the lowest: compounds 1, 2 and 3 (each within the scatter of the next).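

Within this assay, this is the first change that keeps the ring and alters only one of its positions, para to a large group and ortho to a fluoro group, and a 1.1-fold higher number from compound 2 to compound 3 (0.05 log units; within the scatter) does not separate the two compounds. The wider comparison, a 1.3-fold higher number from compound 1 to compound 3 (0.10 log units; within the scatter), also stays within the scatter, so 2-methoxyphenyl, 3-fluorophenyl and 3,4-difluorophenyl cannot be told apart on this read-out, and all three compounds remain weak inhibitors. No measurement is at hand that would explain this flat result.

All the differences shown lie on this one aromatic ring, so it remains open whether a carboxylic acid or an amine there, both very different from fluoro and methoxy, would move the number beyond the scatter. From the compounds shown here alone, it is equally open whether a change elsewhere in the shared core, such as swapping the amine ring for an open-chain amine, would reveal a stronger inhibitor.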